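Replacing the 4-methylphenyl group of compound 3 with hydrogen

The compounds below may be only part of what the source reports. "The series", "measured", "known", "first", "only" and "open" are said of these compounds alone.

Measured in a functional assay on HeLa cells (Homo sapiens) for antiproliferative activity, read by MTT assay, with a stated time of 72 h; a lower number here means a stronger inhibitor, a higher number a weaker inhibitor:
Compound 1 `O=C1O[C@H]([C@@H](O)Cn2cc(-c3cccc(O)c3)nn2)C(OCc2ccccc2)=C1OCc1ccccc1`: 39300 nM
Compound 2 `O=C1O[C@H]([C@@H](O)Cn2cc(CNS(=O)(=O)c3ccc(Cl)cc3)nn2)C(OCc2ccccc2)=C1OCc1ccccc1`: 13600 nM
Compound 3 `Cc1ccc(-c2cn(C[C@H](O)[C@H]3OC(=O)C(OCc4ccccc4)=C3OCc3ccccc3)nn2)cc1`: 25500 nM

Compound 3 cannot be separated from either of the other two compounds. The steps that reach it are a 1.5-fold lower number from compound 1 to compound 3 (0.19 log units; within the scatter) and a 1.9-fold higher number from compound 2 to compound 3 (0.27 log units; within the scatter). Within the data shown here, the only step beyond the scatter is a 2.9-fold lower number from compound 1 to compound 2 (0.46 log units; beyond the scatter), and it is modest.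

Compound 4 `O=C1O[C@H]([C@@H](O)Cn2ccnn2)C(OCc2ccccc2)=C1OCc1ccccc1` follows from compound 3 by hydrogen in place of 4-methylphenyl on an aromatic carbon. All three measured steps exchange one large group for another at this carbon, and none shows what happens with no group there. They therefore bear on the change only indirectly. Among the measured compounds shown here, with all three compounds carrying a large group there, a small move towards a higher number is expected, no larger than the step from compound 1 to compound 2 at most. The expected change is a 1.9-fold higher number from compound 3 to compound 4 (0.27 log units; within the scatter). The estimated value for compound 4 is 48000 nM, with an expected range from 20000 nM to 110000 nM.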

Compound 4, half-maximal inhibitory concentration: > 100000 nM
Compound 4: a limit, no number; the forecaster's own chance of this, stated with the estimate: 20%; at least 2.0-fold (0.31 log units) between middle value and limit.
By their numbers in this assay, from the lowest: compounds 2, 3 and 1 (each within the scatter of the next, the first and the last beyond it). At a limit, above all of these: compound 4.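

In this assay, the reading for compound 4 is a limit of the assay and not a number: the limit of > 100000 nM in this assay, at which 1 of the 4 values shown sits. Taking the group away altogether gives an at least 3.9-fold higher number from compound 3 to compound 4 (0.59 log units; beyond the scatter), and the same comparison with the other two compounds gives an at least 7.3-fold higher number from compound 2 to compound 4 (0.86 log units; beyond the scatter) and an at least 2.5-fold higher number from compound 1 to compound 4 (0.40 log units; beyond the scatter). The earlier compounds showed only that exchanging one large group for another on this aromatic carbon moves the number modestly at most, whereas these steps show that, among the compounds listed, having any of the three groups there gives a lower number than hydrogen does.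

On these data alone, since compound 4 has only a limit, the full size of these steps stays open. As far as these compounds go, it also remains open whether a group as small as methyl or aminomethyl on this carbon would suffice, or whether an aromatic ring or a longer chain is needed.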